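A further hydroxy group on compound 2

A few compounds are considered here, and "the series" means these few. Any claim that something is new, unique, unknown or untested is made for them only; others in the source may bear on it.

- Compound 1 `COc1ccc(-c2nc(NN)n(C)c(=O)c2C#N)cc1`: 39 ug/mL
- Compound 2 `CCOC(=O)c1cnn(-c2nc(-c3ccccc3O)c(C#N)c(=O)n2C)c1N`: 57 ug/mL

In a functional assay on microsomes for inhibition, with a stated time of 1 h (on this read-out higher numbers stand for weaker inhibition and lower numbers for stronger inhibition), compound 2 gives 57 ug/mL and compound 1 gives 39 ug/mL. Among the compounds with values here, these two values lie within the usual scatter of each other, so they set no order between the compounds. Compound 3 `CCOC(=O)c1cnn(-c2nc(-c3cccc(O)c3O)c(C#N)c(=O)n2C)c1N` differs from compound 2 by one change: hydroxy in place of hydrogen on an aromatic carbon, turning 2-hydroxyphenyl into 2,3-dihydroxyphenyl. Within the data shown here, no measured pair shows this change, so the expectation is uncertain. Only a small shift toward stronger inhibition is expected, a 1.6-fold lower number from compound 2 to compound 3 (0.21 log units; within the scatter). For compound 3 the estimated value is 35 ug/mL, with an expected range of 12 ug/mL to 90 ug/mL.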

Compound 3, half-maximal inhibitory concentration: 49 ug/mL
For compound 3 the middle estimate is 1.4-fold (0.15 log units) below the measured one; measured number inside the range.
By their numbers in this assay, from the lowest: compounds 1, 3 and 2 (each within the scatter of the next).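

Putting a hydroxy group on the aromatic ring, which turns 2-hydroxyphenyl into 2,3-dihydroxyphenyl, gives a 1.2-fold lower number from compound 2 to compound 3 (0.07 log units; within the scatter) in this assay. This place on the ring therefore takes a second hydroxy group with no readable effect on this read-out. No other measurement bears on this result. On these data alone, it remains open whether a different group at this same place, such as a methoxy group, an amine or a carboxylic acid, would move the number beyond the scatter. As far as these compounds go, it also remains open whether moving the new hydroxy group elsewhere on the ring would do so.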